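Swapping butylamino for ethoxy on a carbonyl carbon

The source may hold more compounds than are shown below. What is called first, only, known or untested is meant among the compounds shown, and "the series" means these compounds.

compound 1 `CCNC(=O)Nc1cccc2c1CN(C)CC2c1ccccc1`: 54 mg/kg
compound 2 `CCCCNC(=O)Nc1cccc2c1CN(C)CC2c1ccccc1`: 23 mg/kg

In a functional assay on the whole organism for inhibition, with Mus musculus as the target (a higher number here means that more compound is needed for the effect, a lower number that less compound is needed), compound 2 has the lower number of the two measured compounds, at 23 mg/kg, so less of it is needed for the effect. The next compound to be tested is compound 3 `CCOC(=O)Nc1cccc2c1CN(C)CC2c1ccccc1`. Its structural change is ethoxy in place of butylamino on a carbonyl carbon, which means ethoxy in place of butylamino on a carbonyl carbon.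

For the measured compounds named here, only one measured step bears on this change: a 2.3-fold lower number from compound 1 to compound 2 (0.37 log units; beyond the scatter). That step ended at the butylamino group of compound 2, and compound 3 gives this group up for a shorter chain. The move from an amino link to an oxygen link has never been measured on its own in this small set, so this comparison is only a rough guide. A modest step towards a higher number, similar in size to the measured one but in the opposite direction, therefore seems most likely.

The expected change is a 2.2-fold higher number from compound 2 to compound 3 (0.34 log units; beyond the scatter). For compound 3 the estimated value is 50 mg/kg, with an expected range from 15 mg/kg to 150 mg/kg.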

Compound 3, dose for half-maximal effect: about 4 mg/kg
For compound 3 the middle estimate is 13-fold (1.10 log units) above the measured one; measured number outside the range, below it.
By their numbers in this assay, from the lowest: compound 3; then compound 2; then compound 1.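

In this assay, ethoxy in place of butylamino on a carbonyl carbon gives a 5.8-fold lower number from compound 2 to compound 3 (0.76 log units; beyond the scatter), so a shorter chain on an oxygen link outdoes the longer chain on a nitrogen link, even though lengthening the chain on nitrogen had lowered the number in the earlier step. For the compounds shown here, the cleaner comparison keeps the ethyl chain and changes only the link, ethoxy in place of ethylamino, and it gives a 14-fold lower number from compound 1 to compound 3 (1.13 log units; beyond the scatter), a larger step than any seen among the earlier compounds, which places this position's greatest sensitivity so far in the atom joining the chain to the carbonyl rather than in the chain length. No measurement at hand explains why the oxygen link gives the lower number.

On these data alone, it remains open whether the chain effect seen on nitrogen carries over to oxygen, which butoxy on the same carbonyl carbon would test directly. A methoxy group or a branched isopropoxy group would likewise show how much room this position has on the oxygen side, and a plain alkyl chain attached directly to the carbonyl would show how much depends on having an oxygen link at all.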